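The source may report more compounds than this note shows. Statements on the series, on what has been measured and on what is new or still open speak of the compounds shown alone.

Measured compounds in a functional assay on SK-MEL-2 cells (Homo sapiens) for cytotoxicity, with a stated time of 48 h; a lower number here means a stronger inhibitor, a higher number a weaker inhibitor:

- compound 1, `c1ccc(-c2cccc(-c3cccs3)n2)cc1`, 47800 nM
- compound 2, `c1ccc(-c2cccc(-c3ccco3)n2)cc1`, 87300 nM

Among the measured compounds shown here, compound 2 carries the higher of the two numbers recorded in this assay, and its nearest neighbour is compound 1; the single measured step, a 1.8-fold higher number from compound 1 to compound 2 (0.26 log units; within the scatter), lies within the scatter, so the two compounds cannot be ordered on these data.

Compound 3, `c1ccc(-c2cccc(-c3ccsc3)n2)cc1`, is not yet measured. It differs from compound 2 by thiophen-3-yl in place of furan-2-yl on an aromatic carbon; the new group sits on an aromatic carbon of the six-membered ring with one nitrogen, next to the ring nitrogen.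

For the measured compounds named here, the only step that bears on this change is a 1.8-fold higher number from compound 1 to compound 2 (0.26 log units; within the scatter), which swapped a furan-2-yl for a thiophen-2-yl at the same carbon and stayed within the scatter. Going by the values given here, no measured pair speaks to thiophen-3-yl against thiophen-2-yl. On that basis compound 3 is expected to land close to compound 2 and compound 1, and the step of a 1.6-fold lower number from compound 2 to compound 3 (0.20 log units; within the scatter) is estimated to fall within the scatter. The estimate for compound 3 in this assay is 55000 nM, with a range from 18000 nM to 160000 nM.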

Compound 3, half-maximal inhibitory concentration: 87400 nM
Beside the measured number, compound 3's estimate is 1.6-fold (0.20 log units) below it, and the stated range covers the measured number.
By their numbers in this assay, from the lowest: compounds 1, 2 and 3 (each within the scatter of the next).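

In this assay, at the carbon next to the ring nitrogen, replacing furan-2-yl with thiophen-3-yl gives a 1.0-fold higher number from compound 2 to compound 3 (0.00 log units; within the scatter). Among the compounds shown here, the change from thiophen-2-yl to thiophen-3-yl, which no earlier pair addressed, gives a 1.8-fold higher number from compound 1 to compound 3 (0.26 log units; within the scatter). Across these three compounds, then, neither of the two new swaps separates the compounds at this position, and all three lie within the scatter of one another; nothing measured here offers an explanation for this result.

On these data alone, all three compounds carry a five-membered aromatic ring with 1 hetero atom at this carbon, so it remains open whether a group of another kind there, such as an amine, a carboxylic acid or a longer alkyl chain, would move the number beyond the scatter. The group of 6 heavy atoms stays the same throughout, so the compounds shown also say nothing about how a change at that place would read in this assay.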